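Trimming the Amide Substituent on a Naphthylpyridine Acrylamide

The source may hold more compounds than are shown below. What is called first, only, known or untested is meant among the compounds shown, and "the series" means these compounds.

The measured compounds and their values:
Compound 1, `COC1CN(C(=O)/C=C/c2ccncc2-c2ccc3ccccc3c2)C1`, gives 42.8 nM.
Compound 2, `COC(=O)/C=C/c1ccncc1-c1ccc2ccccc2c1`, gives 40.6 nM.
Compound 3, `O=C(O)CCNC(=O)/C=C/c1ccncc1-c1ccc2ccccc2c1`, gives 870 nM.

These three share one core and differ only in the group attached to the carbonyl carbon. In an assay on a protein complex for inhibition of CDK8/Cyclin C (Homo sapiens), with a stated time of 1 h (on this read-out lower numbers stand for stronger inhibition and higher numbers for weaker inhibition), compound 3 stands at the highest number of the three: the steps of a 20-fold higher number from compound 1 to compound 3 (1.31 log units; beyond the scatter) and a 21-fold higher number from compound 2 to compound 3 (1.33 log units; beyond the scatter) are both large and both beyond the scatter, so compound 3 is the weakest inhibitor shown. Compounds 1 and 2 sit close together, as a 1.1-fold lower number from compound 1 to compound 2 (0.02 log units; within the scatter) shows.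

Compound 4, `NC(=O)/C=C/c1ccncc1-c1ccc2ccccc2c1`, has not yet been measured. It differs from compound 3 by hydrogen in place of 2-carboxyethyl on an amide-type nitrogen, so the carbamoyl group remains but the chain that compound 3 carries is gone. The two measured steps leading to compound 3 bear on this change: each time a small group on the carbonyl carbon was exchanged for the (2-carboxyethyl)amino group, the number rose sharply. Among the compounds with values here, removing the 2-carboxyethyl chain again is therefore expected to bring the number back down, toward the region of compounds 1 and 2, though compound 4 carries a group that none of the measured compounds has, so some uncertainty remains. The estimated step is a 15-fold lower number from compound 3 to compound 4 (1.16 log units; beyond the scatter). Compound 4 is expected to give 60 nM, in the range 25 nM to 200 nM.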

Compound 4, half-maximal inhibitory concentration: 10.5 nM
Estimate against measurement, compound 4: 5.7-fold (0.76 log units) above; the whole stated range lies above it.
By their numbers in this assay, from the lowest: compound 4; then compounds 2 and 1 (each within the scatter of the next); then compound 3.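

In this assay, removing the 2-carboxyethyl chain from the amide-type nitrogen gives an 83-fold lower number from compound 3 to compound 4 (1.92 log units; beyond the scatter), so the high number of compound 3 depends on that chain and not on the carbamoyl group that carries it. The bare amino group on the carbonyl carbon also improves on both earlier groups, with a 3.9-fold lower number from compound 2 to compound 4 (0.59 log units; beyond the scatter) replacing methoxy and a 4.1-fold lower number from compound 1 to compound 4 (0.61 log units; beyond the scatter) replacing 3-methoxyazetidin-1-yl; these steps are modest but beyond the scatter, which makes compound 4 the strongest inhibitor of the four. The earlier compounds shown here showed only a pair that could not be told apart and one large loss, whereas compound 4 shows that this position can also move the number below that pair.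

Whether the loss in compound 3 comes from the carboxylic acid at the end of the chain or from the chain itself remains unresolved, and a methyl ester of that chain, a plain propyl chain or a single methyl on the same nitrogen would help separate the two. No measurement here explains why any of these changes has the size it does.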